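The compounds below may be only part of what the source reports. "The series", "measured", "known", "first", "only" and "open" are said of these compounds alone.

In an ADME assay on HFF cells (Homo sapiens) for cytotoxicity, with a stated time of 8 days (a higher number here means that more compound is tolerated, a lower number that less compound is tolerated), compound 1, `Nc1nc(OCC(F)(F)F)c2ncn(/C=C3/CC3(CO)CO)c2n1`, gives > 300000 nM, which is a limit and not a number. Compound 2, `COCCOc1nc(N)nc2c1ncn2/C=C1/CC1(CO)CO`, gives > 300000 nM, which is also a limit. It therefore has no exact position on the scale, and the record so far amounts to this: the limit of > 300000 nM in this assay, at which 2 of the 2 values shown sit.

Compound 3, `CCCCCCCCOc1nc(N)nc2c1ncn2/C=C1/CC1(CO)CO`, keeps the shared core but has hexyl in place of methoxy on a saturated chain carbon, two bonds along the chain from an oxygen on an aromatic ring. Read one bond further out, 2-methoxyethoxy becomes octyloxy.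

Among the compounds with values here, only one measured step bears on this change: a step that the two limits leave unreadable from compound 1 to compound 2, with methoxymethyl in place of trifluoromethyl at that side chain. Its size cannot be read, so it offers no number to carry over, and the expectation rests on the structural change alone. This change is a large one, so a fall in the tolerated concentration in this assay is expected, although compound 3 may also remain at the limit.

The estimated change is an at least 3.7-fold lower number from compound 2 to compound 3 (0.57 log units; beyond the scatter). For compound 3 the expected value is 80000 nM, with an estimated range from 15000 nM to 300000 nM.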

Compound 3, half-maximal cytotoxic concentration: > 300000 nM
Compound 3 ended at the assay's limit; the forecaster's own chance of this, stated with the estimate: 40%; at least 3.7-fold (0.57 log units) between middle value and limit.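

Compound 3 also ends at a limit and not at a number, so its steps from compound 1 and from compound 2 cannot be read, and the record stays as it was: the limit of > 300000 nM in this assay, at which 3 of the 3 values shown sit.

The compounds shown leave open whether any of these side chains would give an exact value in this assay, and how large the differences between them would be.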